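Shortening the Hydroxamate Linker: Three Measured, One Expected

This account rests on a few compounds, and the source may have more. Where it says the series, first, only, none or still open, it means among the compounds named here.

Of the compounds shown here, three have been measured in a functional assay on A549 cells (Homo sapiens) for inhibition; a lower number here means a stronger inhibitor, a higher number a weaker inhibitor. Compound 2 `CC(C)c1cc(-c2n[nH]c(=O)n2-c2cccc(C(=O)NCCCCCCC(=O)NO)c2)c(O)cc1O` gives 4600 nM, and compound 1 `CC(C)c1cc(-c2n[nH]c(=O)n2-c2cccc(C(=O)NCCCCCC(=O)NO)c2)c(O)cc1O` gives 4600 nM. The change between them, (hydroxycarbamoyl in place of (hydroxycarbamoyl)methyl on a saturated chain carbon, five bonds along the chain from an amide-type nitrogen), produced no change at the digits printed from compound 2 to compound 1 (within the scatter). Compound 3 `CC(C)c1cc(-c2n[nH]c(=O)n2-c2ccc(C(=O)NCCCCC(=O)NO)cc2)c(O)cc1O` carries a different core; the difference between the two cores is not broken down here. In this assay compound 3 gives 4600 nM, level with compounds 1 and 2.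

Compound 4 `CC(C)c1cc(-c2n[nH]c(=O)n2-c2ccc(C(=O)NCCCC(=O)NO)cc2)c(O)cc1O` has not been measured and differs from compound 3 by hydroxycarbamoyl in place of (hydroxycarbamoyl)methyl on a saturated chain carbon, three bonds along the chain from an amide-type nitrogen. This is the same kind of change as the earlier one, but its place reads three bonds along the chain from an amide-type nitrogen rather than five. The step is expected to be a 1.2-fold higher number from compound 3 to compound 4 (0.08 log units; within the scatter), resting on the earlier no change at the digits printed from compound 2 to compound 1 (within the scatter). Compound 4 is therefore estimated at 5500 nM, with a range of 2300 nM to 14000 nM.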

Compound 4, half-maximal inhibitory concentration: 4600 nM
Compound 4: middle estimate off by 1.2-fold (0.08 log units), on the high side; measured number inside the range.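

In this assay, putting hydroxycarbamoyl in place of (hydroxycarbamoyl)methyl on the shorter chain gave no change at the digits printed from compound 3 to compound 4 (within the scatter). Set beside the earlier step, the change carried from one core to the other without a visible difference: the same change on two cores in this assay, no change at the digits printed (within the scatter) from compound 2 to compound 1 and no change at the digits printed (within the scatter) from compound 3 to compound 4, 1.0-fold (0.00 log units) apart, within the scatter of two such steps. Within the data shown here, this rests on only two pairs, with the change at a different place on the chain in each, so it does not show that the change would behave the same way on other cores or that chain length is unimportant in general.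

The compounds shown leave open whether a much longer chain on the core of compound 3 would depart from this level. They also leave open what a carboxylic acid in place of hydroxycarbamoyl would do.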